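The source may hold more compounds than are shown below. What is called first, only, known or untested is meant among the compounds shown, and "the series" means these compounds.

Measured compounds:
Compound 1, `COc1ccc(-c2cc(/C=C/C(=O)c3ccc(N)cc3)[nH]n2)cc1`: 1810 nM
Compound 2, `COc1cc(-c2cc(/C=C/C(=O)c3ccc(N)cc3)[nH]n2)cc(OC)c1OC`: 1690 nM

In a functional assay on SF-268 cells (Homo sapiens) for inhibition, read by sulforhodamine B assay, with a stated time of 48 h (a higher number here means a weaker inhibitor of growth, a lower number a stronger inhibitor of growth), compound 1 gives 1810 nM and compound 2 gives 1690 nM. These two numbers lie within the usual scatter of each other, so compound 2 cannot be set apart from compound 1 on this evidence; the two simply share the same level of growth inhibition.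

Compound 3, `COc1cc(-c2cc(/C=C/C(=O)c3ccc(Cl)c(Cl)c3)[nH]n2)cc(OC)c1OC`, has not yet been measured in this assay. It differs from compound 2 in one place: 3,4-dichlorophenyl in place of 4-aminophenyl on a carbonyl carbon. Within the data shown here, no measured pair in this set shows what such an exchange does to the read-out, so there is no step to lean on. Without that, the expectation for compound 3 is a number close to compound 2, with no step beyond the scatter in either direction; the step from compound 2 to compound 3 is estimated as a 1.3-fold lower number from compound 2 to compound 3 (0.11 log units; within the scatter). Compound 3 is therefore estimated at 1300 nM, with a range from 400 nM to 4500 nM.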

Compound 3, concentration for 50% growth inhibition: 13700 nM
Compound 3: middle estimate off by 11-fold (1.02 log units), on the low side; the whole stated range lies below it.
By their numbers in this assay, from the lowest: compounds 2 and 1 (each within the scatter of the next); then compound 3.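

In this assay, 3,4-dichlorophenyl in place of 4-aminophenyl on a carbonyl carbon gives an 8.1-fold higher number from compound 2 to compound 3 (0.91 log units; beyond the scatter), so the read-out depends on the group held at this position. Compound 1 and compound 2 both carry 4-aminophenyl there and could not show this. Nothing available bears on why the exchange has this effect.

Going by these compounds, it remains open whether the weaker growth inhibition of compound 3 follows from losing the amine or from gaining the two chlorines, since this one exchange does both; plain phenyl, 4-chlorophenyl or 4-hydroxyphenyl at the same place would begin to separate the two. On these data alone, it also remains open whether the same exchange would have a similar effect with the 4-methoxyphenyl group of compound 1 in place of the 3,4,5-trimethoxyphenyl group.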